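This account rests on a few compounds, and the source may have more. Where it says the series, first, only, none or still open, it means among the compounds named here.

Of the compounds shown here, three sharing one core have so far been tested in a functional assay on HepG2 cells (Homo sapiens) for inhibition, read by MTT assay; a lower number here means a stronger inhibitor, a higher number a weaker inhibitor. Compound 1 `COc1cc2ncnc(Nc3ccc(NC(=O)c4cccc(F)c4)cc3)c2cc1OC` gives 8200 nM, compound 2 `COc1cc2ncnc(Nc3ccc(NC(=O)c4ccc(F)cc4)cc3)c2cc1OC` gives 15000 nM, and compound 3 `COc1cc2ncnc(Nc3ccc(NC(=O)c4cccc(Cl)c4)cc3)c2cc1OC` gives 12000 nM. Compound 3 lies within the usual scatter of both of the others, so these numbers support no ranking among the three.

The next compound to be tested is compound 4 `COc1cc2ncnc(Nc3ccc(NC(=O)c4cccc(I)c4)cc3)c2cc1OC`, which differs from compound 3 at a single spot: iodo in place of chloro on an aromatic carbon. This is iodo in place of chloro on an aromatic carbon, meta to a large group.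

Going by the values given here, the closest precedent is the exchange of fluoro for chloro, which gave a 1.5-fold higher number from compound 1 to compound 3 (0.17 log units; within the scatter). The two other measured steps are a 1.8-fold higher number from compound 1 to compound 2 (0.26 log units; within the scatter) and a 1.3-fold lower number from compound 2 to compound 3 (0.10 log units; within the scatter). All three are small, and none leaves the scatter. Among the compounds with values here, no compound carrying iodo has been measured yet, so this evidence is indirect and the range has to stay wide. On this basis, no change beyond the scatter is expected in this assay, and the expected step is no change at the digits printed from compound 3 to compound 4 (within the scatter). For compound 4, the estimated value is 12000 nM, with an expected range from 6000 nM to 25000 nM.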

Compound 4, half-maximal inhibitory concentration: 28000 nM
Beside the measured number, compound 4's estimate is 2.3-fold (0.37 log units) below it; the whole stated range lies below it.
By their numbers in this assay, from the lowest: compounds 1, 3, 2 and 4 (each within the scatter of the next, the first and the last beyond it).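

In this assay, the group on this aromatic carbon now makes a measurable difference: iodo in place of chloro gives a 2.3-fold higher number from compound 3 to compound 4 (0.37 log units; beyond the scatter) and so leaves the scatter, which none of the three earlier steps did. Iodo in place of fluoro at the same spot gives a 3.4-fold higher number from compound 1 to compound 4 (0.53 log units; beyond the scatter) as a second step beyond the scatter, so iodo can be told apart from both smaller halogens here, even though fluoro and chloro could not be told apart from each other. The change from 4-fluorophenyl to 3-iodophenyl gives a 1.9-fold higher number from compound 2 to compound 4 (0.27 log units; within the scatter) and stays within the scatter, so compound 4 does not stand clear of every other compound, and the effect of iodo is only secure for exchanges at this one position.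

The data offered here contain no measurement that would explain why iodo behaves differently from chloro or fluoro at this position. A bromo group on the same carbon would show whether the number climbs in steps through the halogens, while a methyl group or an amine there would show whether this behaviour belongs to halogens at all.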